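The source may report more compounds than this note shows. Statements on the series, on what has been measured and on what is new or still open speak of the compounds shown alone.

Compound 1, whose structure is `O=C(CC1CCCCC1)N1CCN(c2nc(=O)c3cc(C(F)(F)F)cc([N+](=O)[O-])c3s2)CC1`, sits at the bottom of the three measured compounds in a physicochemical assay for solubility, read by HPLC (a lower number here means a less soluble compound, a higher number a more soluble compound), where compound 1 gives 0.12 ug/mL. Its two neighbours on the numbers are compound 2, with the structure `CC(C)(C)C(=O)N1CCN(c2nc(=O)c3cc(C(F)(F)F)cc([N+](=O)[O-])c3s2)CC1`, and compound 3, with the structure `O=C(C1CCCC1)N1CCN(c2nc(=O)c3cc(C(F)(F)F)cc([N+](=O)[O-])c3s2)CC1`; in this assay compound 2 gives 5.87 ug/mL and compound 3 gives 5.34 ug/mL. The two steps away from compound 1 are both large: a 49-fold higher number from compound 1 to compound 2 (1.69 log units; beyond the scatter), and a 45-fold higher number from compound 1 to compound 3 (1.65 log units; beyond the scatter). Between the two higher compounds there is no separation, since a 1.1-fold lower number from compound 2 to compound 3 (0.04 log units; within the scatter).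

Compound 4, with the structure `O=C(c1ccc(F)cc1)N1CCN(c2nc(=O)c3cc(C(F)(F)F)cc([N+](=O)[O-])c3s2)CC1`, differs from compound 1 in one place: 4-fluorophenyl in place of cyclohexylmethyl on a carbonyl carbon. Within the data shown here, no measured step exchanges the cyclohexylmethyl for an aromatic group, so the two steps that bear on it only indirectly are a 49-fold higher number from compound 1 to compound 2 (1.69 log units; beyond the scatter) and a 45-fold higher number from compound 1 to compound 3 (1.65 log units; beyond the scatter), which show that every replacement of the cyclohexylmethyl seen so far gave a large rise in this assay. Compound 4 is therefore expected to lie above compound 1 by a step of roughly a 17-fold higher number from compound 1 to compound 4 (1.22 log units; beyond the scatter), with wide uncertainty. The estimate for compound 4 in this assay is 2 ug/mL, with a range from 0.3 ug/mL to 12 ug/mL.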

Compound 4, solubility: 1.69 ug/mL
Estimate against measurement, compound 4: 1.2-fold (0.07 log units) above; the measured number falls inside the stated range.
By their numbers in this assay, from the lowest: compound 1; then compound 4; then compounds 3 and 2 (each within the scatter of the next).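

Among these compounds, with 4-fluorophenyl, an aromatic ring stands on the carbonyl carbon for the first time, and in this assay the large gain over cyclohexylmethyl largely survives, with a 14-fold higher number from compound 1 to compound 4 (1.15 log units; beyond the scatter); the gain therefore does not depend on a non-aromatic group, and it appears here with the heavy-atom count unchanged. The gain is nevertheless smaller than with the two non-aromatic replacements, since there is a 3.2-fold lower number from compound 3 to compound 4 (0.50 log units; beyond the scatter) and a 3.5-fold lower number from compound 2 to compound 4 (0.54 log units; beyond the scatter), so the position now shows three levels rather than the two seen earlier: cyclohexylmethyl lowest, 4-fluorophenyl in the middle, and cyclopentyl and tert-butyl together at the top. Nothing available accounts for these differences between the groups.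

The compounds shown cannot separate the contribution of the fluorine from that of the aromatic ring, which unsubstituted phenyl on the same carbonyl carbon would address, nor the contribution of the ring size from that of the extra methylene, which cyclohexyl attached directly to the carbonyl would address. Going by these compounds, how an amine or a carboxylic acid at this position would read in this assay also remains open.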